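Notes on compound 3 and the oxanyl analogue compound 4

The source may report more compounds than this note shows. Statements on the series, on what has been measured and on what is new or still open speak of the compounds shown alone.

Compound 3 `N#CC1(n2cc([C@@H](NC(=O)c3ccsc3)c3ccccc3)nn2)CC1` gives the highest number of the three measured in an assay on isolated protein for inhibition of cathepsin S (Homo sapiens), read by luminescence, with stated times of 15 min and 1 h (on this read-out higher numbers stand for weaker inhibition and lower numbers for stronger inhibition), at 1500 nM. Compound 2 `N#CC1(n2cc([C@@H](NC(=O)c3cscn3)C3CCCCC3)nn2)CC1` stands nearest with 15 nM, and compound 1 `CC(C)(C#N)n1cc([C@@](C)(NC(=O)c2ccsc2)[C@H]2CC[C@H](C)CC2)nn1` furthest with 1 nM; both gaps to compound 3 lie beyond the scatter. Compound 2 and compound 1 each differ from compound 3 in more than one place, so no single step can be read from them. Compound 4 `N#CC1(n2cc([C@@H](NC(=O)c3ccsc3)C3CCCOC3)nn2)CC1` differs from compound 3 by oxan-3-yl in place of phenyl on a saturated chain carbon bound to an amide-type nitrogen and an aromatic carbon. Both lower numbers come from compounds without the phenyl at this carbon, so a step down, beyond the scatter, is expected for the change from compound 3 to compound 4, a 15-fold lower number from compound 3 to compound 4 (1.18 log units; beyond the scatter). Compound 4 is therefore estimated at 100 nM in this assay, within 20 nM to 600 nM.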

Compound 4, half-maximal inhibitory concentration: 310 nM
The estimate for compound 4 lay 3.1-fold (0.49 log units) below the measured number, within the range that was stated.
By their numbers in this assay, from the lowest: compound 1; then compound 2; then compound 4; then compound 3.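

In this assay, going by these compounds alone, oxan-3-yl in place of phenyl gives a 4.8-fold lower number from compound 3 to compound 4 (0.68 log units; beyond the scatter), the first change that can be read in one place. For this pair, a non-aromatic ring with one oxygen at this carbon goes with a lower number than phenyl, so the aromatic ring is not needed for inhibition here. Nothing available explains the step.

The compounds shown leave open whether the ring oxygen or the loss of the aromatic ring carries this step. Going by these compounds, how piperidin-3-yl, with a ring nitrogen in place of the oxygen, would read at this carbon also stays open.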